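A few compounds are considered here, and "the series" means these few. Any claim that something is new, unique, unknown or untested is made for them only; others in the source may bear on it.

Values in a functional assay on MCF7 cells (Homo sapiens) for antiproliferative activity, read by MTT assay, with a stated time of 72 h; on this read-out lower numbers stand for stronger inhibition and higher numbers for weaker inhibition:
- Compound 1 `CCCCCc1ccc(-c2cn(C[C@H](O)[C@H]3OC(=O)C(OCc4ccccc4)=C3OCc3ccccc3)nn2)cc1`: 9010 nM
- Compound 2 `O=C1O[C@H]([C@@H](O)Cn2ccnn2)C(OCc2ccccc2)=C1OCc1ccccc1`: > 100000 nM (a limit)

Compound 2 stands at > 100000 nM, which is a limit of the assay and not a number. Compound 3 `O=C1O[C@H]([C@@H](O)Cn2cc(CCO)nn2)C(OCc2ccccc2)=C1OCc1ccccc1` differs from it in one place: 2-hydroxyethyl in place of hydrogen on an aromatic carbon. Among the compounds with values here, the only measured step at such a carbon is large: an at least 11-fold higher number from compound 1 to compound 2 (1.04 log units; beyond the scatter). That step involves 4-pentylphenyl, whereas the 2-hydroxyethyl has no ring, so it offers only weak guidance here. Only a modest move towards stronger inhibition is expected, possibly none beyond the scatter. The expected step is an at least 1.1-fold lower number from compound 2 to compound 3 (0.04 log units; that floor lies within the scatter). For compound 3 the estimated value is 90000 nM, with an expected range of 30000 nM to 200000 nM.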

Compound 3, half-maximal inhibitory concentration: 63400 nM
Compound 3: middle estimate off by 1.4-fold (0.15 log units), on the high side, within the range that was stated.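

In this assay compound 2 stands at > 100000 nM, which is a limit of the assay and not a number. With 2-hydroxyethyl on this aromatic carbon the read-out becomes a real number, but the step is only an at least 1.5-fold lower number from compound 2 to compound 3 (0.19 log units; that floor lies within the scatter), so no true gain over hydrogen can be claimed: the limit of > 100000 nM in this assay, at which 1 of the 3 values shown sits. The ringless chain also falls well short of 4-pentylphenyl, with a 7.0-fold higher number from compound 1 to compound 3 (0.85 log units; beyond the scatter).

On these data alone, whether an amine, a carboxylic acid or a longer chain at this carbon would come closer to compound 1 remains open. So does whether the ring or the pentyl chain of 4-pentylphenyl accounts for the difference.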